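Resolving the stereocentre of compound 2

This account rests on a few compounds, and the source may have more. Where it says the series, first, only, none or still open, it means among the compounds named here.

Measured so far in an assay on HEK293 cells for displacement of a labelled ligand from Neuronal acetylcholine receptor; alpha3/beta4 (Homo sapiens), read by scintillation counting, with a stated time of 120 min; a lower number here means a stronger inhibitor, a higher number a weaker inhibitor:
compound 1, `c1ccc(COc2cccc(-c3cn([C@@H]4CN5CCC4CC5)nn3)c2)cc1`: 6.67 nM
compound 2, `Fc1ccc(COc2cccc(-c3cn(C4CN5CCC4CC5)nn3)c2)cc1`: 13.9 nM

Compound 2 stands at the higher of the two numbers in this assay; its nearest neighbour, compound 1, lies lower by a margin beyond the usual scatter. Compound 1 carries the configured stereocentre that compound 2 lacks, and a benzyloxy group without fluorine in place of the fluorinated one.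

Compound 3, `Fc1ccc(COc2cccc(-c3cn([C@@H]4CN5CCC4CC5)nn3)c2)cc1`, is the next compound. The change from compound 2 to compound 3 is the two compounds have the same atoms and bonds; at least one stereo element is drawn with a configuration in one of them and without one in the other: 1 of 3 stereo elements differ; a stereocentre at a saturated ring carbon is drawn without a configuration in compound 2 and S in compound 3. The atoms and bonds do not change; only the drawn configuration at the saturated ring carbon does.

For the measured compounds named here, no step between two measured compounds isolates this change. If the configured form carries the activity of the undefined form, the number in this assay should move downward, by a step that may reach beyond the scatter but need not. Compound 3 is accordingly expected at 7.5 nM, within 3 nM to 20 nM, an estimated step of a 1.9-fold lower number from compound 2 to compound 3 (0.27 log units; within the scatter).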

Compound 3, inhibition constant: 7.17 nM
Beside the measured number, compound 3's estimate is 1.0-fold (0.02 log units) above it; the range from low to high includes it.
By their numbers in this assay, from the lowest: compounds 1, 3 and 2 (each within the scatter of the next, the first and the last beyond it).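

In this assay the defined S form comes with a 1.9-fold lower number from compound 2 to compound 3 (0.29 log units; within the scatter), which does not separate the S drawing from the undefined one, and the only difference in play is this: the fact that one of compounds 2 and 3 is drawn with a defined configuration and the other without, at the place where they differ

With the configuration held at S, fluoro in place of hydrogen on an aromatic carbon gives a 1.1-fold higher number from compound 1 to compound 3 (0.03 log units; within the scatter), so this replacement is not resolved in this assay either. Compound 1 and compound 2 differ in two places and could not assign anything to either change; each change now stands alone, and neither step on its own reaches beyond the scatter.

Still open, going by these compounds, is the R configuration at the saturated ring carbon, which would show whether this stereocentre matters at all in this assay, and the composition of compound 2 is not stated, so its undefined drawing cannot be read as a known mixture of forms. Also open, on these data alone, is how far the benzyloxy end tolerates larger changes than fluoro for hydrogen, such as a chloro or methoxy group on the aromatic ring, or a longer chain in place of the benzyloxy group.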